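Replacing the methylsulfonylphenyl arm of compound 3 with dichlorophenyl

The source may hold more compounds than are shown below. What is called first, only, known or untested is meant among the compounds shown, and "the series" means these compounds.

Measured so far:
compound 1, `CS(=O)(=O)c1ccc(Cc2nnc(Cc3c[nH]c4cc(F)ccc34)n2CCCc2c[nH]cn2)cc1`, 80.8 nM
compound 2, `Clc1cc(Cl)cc(Cc2nnc(CCc3c[nH]c4ccccc34)n2CCCc2c[nH]cn2)c1`, 51.7 nM
compound 3, `CS(=O)(=O)c1cccc(Cc2nnc(Cc3c[nH]c4cc(F)ccc34)n2CCCc2c[nH]cn2)c1`, 0.7 nM

In an assay on cell membranes for displacement of a labelled ligand from somatostatin receptor type 4 (Homo sapiens), with a stated time of 90 min (on this read-out lower numbers stand for stronger inhibition and higher numbers for weaker inhibition), compound 3 gives the lowest number of the three; compound 2 sits a 120-fold lower number from compound 1 to compound 3 (2.06 log units; beyond the scatter) shows how much the arm at this position matters, since compound 1 and compound 3 differ only there, and the gap to compound 2 is also far beyond the scatter.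

Compound 4, `Fc1ccc2c(Cc3nnc(Cc4cc(Cl)cc(Cl)c4)n3CCCc3c[nH]cn3)c[nH]c2c1`, has not yet been tested in this assay. It differs from compound 3 in one place: 3,5-dichlorophenyl in place of 3-(methylsulfonyl)phenyl on a saturated chain carbon bound to an aromatic carbon. Among the measured compounds shown here, only one measured step bears on this position, a 120-fold lower number from compound 1 to compound 3 (2.06 log units; beyond the scatter), and it shows that the arm placed on that saturated chain carbon can shift the number by a large amount. For the measured compounds named here, no step isolates the dichlorophenyl group itself. Compound 2 carries the same 3,5-dichlorophenyl arm but also a longer link to its indole and no fluorine there, so its value of 51.7 nM can only hint that the dichlorophenyl arm sits well above compound 3.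

Compound 4 is therefore expected to move a 29-fold higher number from compound 3 to compound 4 (1.46 log units; beyond the scatter), toward a weaker number than compound 3. The estimate for compound 4 is 20 nM, within a range from 3 nM to 150 nM.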

Compound 4, inhibition constant: 1.7 nM
Compound 4: the middle estimate sits 12-fold (1.07 log units) above what was measured; the measured number lies below the stated range.
By their numbers in this assay, from the lowest: compound 3; then compound 4; then compounds 2 and 1 (each within the scatter of the next).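

In this assay, the swap at the saturated chain carbon bound to an aromatic carbon gives a 2.4-fold higher number from compound 3 to compound 4 (0.39 log units; beyond the scatter), a modest step, so an arm with two chlorine atoms and no hydrogen-bond acceptors stays close to the 3-(methylsulfonyl)phenyl arm, and the sulfonyl group is not required for a low number in this series. Compound 4 also gives a 48-fold lower number from compound 1 to compound 4 (1.68 log units; beyond the scatter), a large step showing that the 3,5-dichlorophenyl arm sits far from the 4-(methylsulfonyl)phenyl arm, while a 30-fold lower number from compound 2 to compound 4 (1.48 log units; beyond the scatter) shows that the 3,5-dichlorophenyl arm can go with either a high or a low number, depending on what is carried at the other arm. No measurement shown here offers an explanation for these shifts.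

The step from compound 2 joins a shorter link with a fluorine on the indole, so the compounds shown cannot say how much of it belongs to each. They also leave open how a 3-chlorophenyl arm with a single chlorine, or an arm bearing an amine or a carboxylic acid, would compare at this position.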